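From a Bromomethyl to an Acetoxymethyl Group

This account rests on a few compounds, and the source may have more. Where it says the series, first, only, none or still open, it means among the compounds named here.

Two measured compounds share one core and differ in a single group. Compound 1 `CCOC(=O)c1c(C)coc1-c1ccc2c(CC)cccc2c1OC` carries an ethoxycarbonyl group on an aromatic carbon, and in a functional assay on DU-145 cells (Homo sapiens) for cytotoxicity, read by MTT assay, with a stated time of 72 h (a lower number here means that less compound is needed, a higher number that more compound is needed for the effect), compound 1 gives 2.2 ug/mL. Compound 2 `CCc1cccc2c(OC)c(-c3occ(C)c3CBr)ccc12` carries a bromomethyl group in its place. In this assay compound 2 shows only > 10 ug/mL, which is a limit of the measurement and not a number. The step of an at least 4.5-fold higher number from compound 1 to compound 2 (0.65 log units; beyond the scatter) is thus known only as a bound, set by the limit of > 10 ug/mL in this assay, at which 1 of the 2 values shown sits.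

Compound 3 `CCc1cccc2c(OC)c(-c3occ(C)c3COC(C)=O)ccc12` makes the next change: acetoxy in place of bromo on a saturated chain carbon bound to an aromatic carbon. Within the data shown here, the one measured step concerns a different exchange, so it bears on this change only loosely, and the limit on compound 2 leaves the starting point open. For compound 3 the expected value in this assay is 5 ug/mL, within a range from 1.5 ug/mL to 20 ug/mL. The step of an at least 2.0-fold lower number from compound 2 to compound 3 (0.30 log units; that floor lies within the scatter) is estimated to be toward a lower number, with its size uncertain.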

Compound 3, concentration for half-maximal effect: > 10 ug/mL
Compound 3: a limit, no number; the forecaster's own chance of this, stated with the estimate: 40%; at least 2.0-fold (0.30 log units) between middle value and limit.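

In this assay compound 3 gives > 10 ug/mL, which is a limit of the assay and not a number. The exchange of ethoxycarbonyl for acetoxymethyl on an aromatic carbon gives an at least 4.5-fold higher number from compound 1 to compound 3 (0.65 log units; beyond the scatter), so acetoxymethyl now joins bromomethyl as a second group that needs more compound for the effect than the ethoxycarbonyl group does. The exchange of bromo for acetoxy cannot be read, since neither compound gives a number: the limit of > 10 ug/mL in this assay, at which 2 of the 3 values shown sit.

As far as these compounds go, how much compound either one would truly need remains unknown, so compound 2 and compound 3 cannot be ranked against each other. From the compounds shown here alone, it also remains open whether a carboxylic acid, an amine or a longer ester chain in this place would bring the number back toward that of compound 1.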